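Methyl on the Amide Nitrogen in Two Related Cores

The compounds below may be only part of what the source reports. "The series", "measured", "known", "first", "only" and "open" are said of these compounds alone.

Compound 1, `CNC(=O)/C=C1\CCc2ccc(Br)cc21`: 53%
Compound 2, `NC(=O)/C=C1\CCc2cc(Cl)ccc21`: 29%
Compound 3, `NC(=O)/C=C1\CCc2ccc(Br)cc21`: 21%

All three compounds were tested in a functional assay on the whole organism with Rattus norvegicus as the target, at a dose of 20 mg/kg by the oral route; a lower number here means less inhibition, a higher number more inhibition at the dose given (going by the name of the read-out). Compound 1 gives 53%, compound 2 gives 29% and compound 3 gives 21%. The values of compound 2 and compound 3 lie within the usual scatter of each other, so nothing separates them. Compound 1, however, stands apart: the step of a number 32 percentage points higher from compound 3 to compound 1 (beyond the scatter) is large and beyond the scatter. Among the compounds with values here, the only change between these two is methyl in place of hydrogen on an amide-type nitrogen.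

The same change is now to be made on the other core. Compound 4, `CNC(=O)/C=C1\CCc2cc(Cl)ccc21`, differs from compound 2 by methyl in place of hydrogen on an amide-type nitrogen. Compound 2 and compound 3 differ in their cores, and the difference between the two cores is not broken down here. Since the place of the change is the same in both pairs, this is the same change seen once already.

In this assay, the step from compound 2 to compound 4 is expected to be a number 27 percentage points higher from compound 2 to compound 4 (beyond the scatter), close to the earlier step, because the step of a number 32 percentage points higher from compound 3 to compound 1 (beyond the scatter) was large and the starting values of compound 2 and compound 3 are within the scatter of each other. Within the data shown here, with only one earlier example, the range is kept wide. Compound 4 is therefore estimated at 56%, with a likely span from 36% to 74%.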

Compound 4, a percentage reported as inhibition, in the whole organism at one dose (the size of the read-out at that dose, not a potency): 44%
The estimate for compound 4 lay 12 percentage points above the measured number, within the range that was stated.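

In this assay, methyl in place of hydrogen on the amide-type nitrogen moves the number the same way on the second core, giving a number 15 percentage points higher from compound 2 to compound 4 (beyond the scatter), so the direction of the change carries over from one core to the other. The size does not carry over unchanged, so a step seen on one core is a guide to the direction on the other rather than a figure to copy: the same change on two cores in this assay, a number 32 percentage points higher (beyond the scatter) from compound 3 to compound 1 and a number 15 percentage points higher (beyond the scatter) from compound 2 to compound 4, 17 percentage points apart, beyond the scatter of two such steps

Within the data shown here, with only two pairs, this does not show which feature of the cores goes with the larger or the smaller step, or whether the direction would hold on a third core, and each number describes inhibition at a single dose rather than potency.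

Among the compounds shown, the amide-type nitrogen carries only hydrogen or methyl, so it remains open how an ethyl group or a longer chain would read there. On these data alone, it also remains open whether the methyl step would keep its direction on a core with a fluorine atom in place of the bromine or chlorine.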